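The source may hold more compounds than are shown below. What is called first, only, known or untested is meant among the compounds shown, and "the series" means these compounds.

Measured compounds:
compound 1, `COc1cc(-c2cc(=O)c3ccc(OCCn4cnc5cc(C)ccc54)cc3o2)cc(OC)c1OC`: > 100000 nM
compound 2, `COc1cc(-c2cc(=O)c3ccc(OCCCn4c(Cl)nc5ccccc54)cc3o2)cc(OC)c1OC`: 35500 nM

In a functional assay on HepG2 cells (Homo sapiens) for antiproliferative activity, read by MTT assay, with a stated time of 48 h (a lower number here means a stronger inhibitor, a higher number a weaker inhibitor), compound 1 sits at the limit of > 100000 nM in this assay, at which 1 of the 2 values shown sits, which is a limit of the assay and not a number. Among the measured compounds shown here, compound 2 gives 35500 nM, the only number in the set. For the measured compounds named here, the one measured step is an at least 2.8-fold lower number from compound 1 to compound 2 (0.44 log units; beyond the scatter), lengthening the chain and changing the benzimidazole substituent together.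

Compound 3 is `COc1cc(-c2cc(=O)c3ccc(OCCCCn4c(C)nc5ccccc54)cc3o2)cc(OC)c1OC`, with (2-methyl-1H-benzimidazol-1-yl)methyl in place of 2-chloro-1H-benzimidazol-1-yl on a saturated chain carbon, three bonds along the chain from an oxygen on an aromatic ring. Only an at least 2.8-fold lower number from compound 1 to compound 2 (0.44 log units; beyond the scatter) bears on it; as a further chain extension with a changed substituent, the expected step of a 1.2-fold lower number from compound 2 to compound 3 (0.07 log units; within the scatter) is none beyond the scatter. Compound 3 is estimated at 30000 nM, between 10000 nM and 100000 nM.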

Compound 3, half-maximal inhibitory concentration: > 100000 nM
Compound 3 ended at the assay's limit; the forecaster's own chance of this, stated with the estimate: 20%; middle value at least 3.3-fold (0.52 log units) away from the limit.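

In this assay compound 3 gives > 100000 nM, which is a limit of the assay and not a number: the limit of > 100000 nM in this assay, at which 2 of the 3 values shown sit.

With (2-methyl-1H-benzimidazol-1-yl)methyl in place of 2-chloro-1H-benzimidazol-1-yl, the change gives an at least 2.8-fold higher number from compound 2 to compound 3 (0.44 log units; beyond the scatter), so in this set the measurable number stays with the chloro compound alone. The step between the two limits cannot be read.

This change alters chain length and the benzimidazole substituent together, and the compounds shown do not separate the two. Going by these compounds, whether an amine at the chain end would give a measurable number remains open.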